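Bromo to fluoro on the shared core: expected inhibition

The source may hold more compounds than are shown below. What is called first, only, known or untested is meant among the compounds shown, and "the series" means these compounds.

Measured so far, in a functional assay on the whole organism with Mus musculus as the target, with a stated time of 1 h, at a dose of 100 mg/kg by the intraperitoneal route; a higher number here means more inhibition at the dose given (going by the name of the read-out), a lower number less inhibition:
compound 1, `Brc1ccc(OCCOc2nc3ccccc3s2)c(Br)c1`, compound 1 gives 87.3%
compound 2, `Brc1ccc(OCCOc2nc3ccccc3s2)cc1`, compound 2 gives 94.6%
compound 3, `Brc1cccc(COc2nc3ccccc3s2)c1`, compound 3 gives 77.6%

Among the three, compound 2 carries the largest figure in this assay. Its gap to compound 1 is within the scatter, so the two cannot be ordered; compound 3 lies beyond the scatter below compound 2.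

Compound 4, `Fc1ccc(OCCOc2nc3ccccc3s2)cc1`, has not been measured in this assay. Its change from compound 2 is fluoro in place of bromo on an aromatic carbon.

For the measured compounds named here, one measured step bears on this change: a number 7.3 percentage points higher from compound 1 to compound 2 (within the scatter). That step removes a bromo from an aromatic carbon altogether and still leaves the number where it was, within the scatter. Exchanging bromo for fluoro at the other ring position is a smaller alteration of the same kind, and nothing else in the series speaks to a halogen on this carbon. No step beyond the scatter is therefore expected in this assay.

For compound 4 the estimate in this assay is 88%, with a range from 72% to 100%. The implied step, a number 6.6 percentage points lower from compound 2 to compound 4 (within the scatter), is expected to remain within the scatter.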

Compound 4, a percentage reported as inhibition, in the whole organism at one dose (the size of the read-out at that dose, not a potency): 72.7%
Estimate against measurement, compound 4: 15.3 percentage points above; low and high end bracket the measured number.
By their numbers in this assay, from the lowest: compounds 4, 3, 1 and 2 (each within the scatter of the next, the first and the last beyond it).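

In this assay, the identity of the halogen on this aromatic carbon, para to a large group, proves to count: fluoro in place of bromo gives a number 21.9 percentage points lower from compound 2 to compound 4 (beyond the scatter). For the compounds shown here, the only earlier step, a number 7.3 percentage points higher from compound 1 to compound 2 (within the scatter), concerned the other bromo of compound 1 and a loss of that atom, so its reading does not carry over to this carbon, where a swap of one heavy atom for another with the same counts of donors, acceptors and charge is enough to move the number beyond the scatter. No measurement at hand accounts for this step, which therefore stands as an observation only.

With only bromo and fluoro shown at this carbon, it remains open whether the number tracks the halogen in some graded way or whether bromo alone holds it up, and chloro, iodo, methyl, methoxy or plain hydrogen at the same place would separate those readings. Also open, as far as these compounds go, is whether the same exchange behaves alike on the shorter link of compound 3, and how a longer chain between the two ring systems or an amine on the benzene ring would read at this single dose.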